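Ring amine substituent and cytotoxicity in a small series

The source may hold more compounds than are shown below. What is called first, only, known or untested is meant among the compounds shown, and "the series" means these compounds.

Three measured compounds share one core and differ in the amine attached to it. Compound 1 `CC1CCCN(C(=S)SC(=S)N(C)C)C1` gives in an ADME assay on HeLa cells (Homo sapiens) for cytotoxicity, read by MTT assay, with a stated time of 24 h (on this read-out lower numbers stand for stronger inhibition and higher numbers for weaker inhibition), a value of 2900000 nM. Compound 2 `CCN(CC)C(=S)SC(=S)N(C)C` gives in this assay only > 5000000 nM, which is a limit of the assay and not a number. For compound 2 this is the limit of > 5000000 nM in this assay, at which 1 of the 3 values shown sits. Compound 3 `CN1CCN(C(=S)SC(=S)N(C)C)CC1` gives 1220000 nM in this assay, the lowest of the two numbers shown; compound 1 stands nearest, with a higher number, and that gap lies beyond the usual scatter. Compound 2 cannot be placed in this order because its result is a limit.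

Compound 4 `CCOC(=O)N1CCN(C(=S)SC(=S)N(C)C)CC1` is not yet measured in this assay. It differs from compound 3 by ethoxycarbonyl in place of methyl on an amine nitrogen in a ring. For the measured compounds named here, no pair of measured compounds differs in a single place, so no measured step describes this change, and none of the three measured compounds carries an ethoxycarbonyl group. The expectation is therefore a step of modest size toward a higher number, close to the scatter, estimated as a 1.6-fold higher number from compound 3 to compound 4 (0.21 log units; within the scatter). Compound 4 is expected at 2000000 nM, with a range from 800000 nM to 5000000 nM.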

Compound 4, half-maximal inhibitory concentration: 530000 nM
Beside the measured number, compound 4's estimate is 3.8-fold (0.58 log units) above it; the measured number lies below the stated range.
By their numbers in this assay, from the lowest: compound 4; then compound 3; then compound 1. At a limit, above all of these: compound 2.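

In this assay, for the compounds shown here, ethoxycarbonyl in place of methyl on an amine nitrogen in a ring gives a 2.3-fold lower number from compound 3 to compound 4 (0.36 log units; beyond the scatter) and so supplies the first single-place step, one that lies beyond the scatter. At this position, a group with more heavy atoms and with hydrogen-bond acceptors, which methyl lacks, goes with a lower number rather than a higher one, although this rests on a single pair of compounds. Nothing among the data shown accounts for the direction or size of this step.

On these data alone, a single pair cannot separate the contributions of the carbonyl, the ethoxy part and the overall size of the entering group, so it remains open whether an ethyl group, an acetyl group or a longer chain on the same ring nitrogen would give a similar step. As far as these compounds go, it also remains open whether a free carboxylic acid or a primary amine at the end of such a group would follow the same direction in this read-out.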